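The source may hold more compounds than are shown below. What is called first, only, known or untested is meant among the compounds shown, and "the series" means these compounds.

For the measured compounds named here, in an ADME assay on microsomes from liver (Rattus norvegicus) for metabolic stability, with a stated time of 10 min (on this read-out higher numbers stand for a more stable compound and lower numbers for a less stable compound), compound 3 (`COCCCc1cc(-c2ccc(Cl)cc2)n(-c2ccccc2OC)n1`) gives 4%, the lowest of the three numbers measured so far. Compound 1 (`COc1ccccc1-n1nc([C@H]2C[C@@H](C)O[C@@H](C)C2)cc1-c1ccc(Cl)cc1`) gives 18%, and compound 2 (`COc1ccccc1-n1nc(C2CC(C)(C)OC(C)(C)C2)cc1-c1ccc(Cl)cc1`) gives 96%. Compound 4 (`COc1ccccc1-n1nc(C2CCOC(C)(C)C2)cc1-c1ccc(Cl)cc1`) keeps the shared core but carries 2,2-dimethyloxan-4-yl in place of 3-methoxypropyl on an aromatic carbon.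

Going by the values given here, three measured steps bear on this change. The closest is a number 14 percentage points lower from compound 1 to compound 3 (beyond the scatter), a modest step beyond the scatter. The other two are large: a number 92 percentage points lower from compound 2 to compound 3 (beyond the scatter) and a number 78 percentage points higher from compound 1 to compound 2 (beyond the scatter). The group in compound 4 matches neither the 2,6-dimethyloxan-4-yl of compound 1 nor the 2,2,6,6-tetramethyloxan-4-yl of compound 2, so these steps only frame the expectation. Compound 4 lacks the full tetramethyl pattern of compound 2, which alone reaches 96%, so a rise of modest size, with a wide margin upward, is expected. The expected step is a number 24 percentage points higher from compound 3 to compound 4 (beyond the scatter). Compound 4 is estimated at 28%, with an expected range from 8% to 60%.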

Compound 4, percent of the compound remaining: 21%
Compound 4: the middle estimate sits 7 percentage points above what was measured, and the stated range covers the measured number.
By their numbers in this assay, from the lowest: compound 3; then compounds 1 and 4 (each within the scatter of the next); then compound 2.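

In this assay, a ring at this position does give a gain over the open chain, a number 17 percentage points higher from compound 3 to compound 4 (beyond the scatter), but that gain is modest. The 2,2-dimethyloxan-4-yl group cannot be told apart from the 2,6-dimethyloxan-4-yl group, with a number 3 percentage points higher from compound 1 to compound 4 (within the scatter), so these two arrangements of two methyl groups on the ring read the same here. The large change comes only with the 2,2,6,6-tetramethyloxan-4-yl group, as a number 75 percentage points lower from compound 2 to compound 4 (beyond the scatter) shows, and among these four compounds only compound 2 holds a high number.

No measurement at hand explains these differences. The compounds shown leave open whether 2,2,6-trimethyloxan-4-yl would stay with compound 4 or approach compound 2, and how plain oxan-4-yl or a tetramethylpiperidin-4-yl group, with an amine in the ring, would behave.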